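The source may report more compounds than this note shows. Statements on the series, on what has been measured and on what is new or still open speak of the compounds shown alone.

Measured compounds:
Compound 1 `C=CCn1c(=O)/c(=C\c2ccc(Cl)c(Cl)c2)[nH]c(=O)/c1=C\c1ccccc1OC` in a functional assay on U-937 cells (Homo sapiens) for cytotoxicity, read by CCK-8 assay, with a stated time of 72 h; on this read-out lower numbers stand for stronger inhibition and higher numbers for weaker inhibition: "not active" (no number reported)
Compound 2 `COc1ccccc1/C=c1\c(=O)[nH]/c(=C/c2cccc(Cl)c2Cl)c(=O)n1C` in this assay: 100 nM
Compound 3 `C=CCn1c(=O)/c(=C\c2cccc(Br)c2)[nH]c(=O)/c1=C\c1cccc(Br)c1` in this assay: "not active" (no number reported)

Compound 1 stands without a number: in this assay it is recorded only as not active, and compound 3 carries the same remark, so neither can be placed against the other. Compound 2 alone has a numeric reading among these three.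

Compound 4 `C=CCn1c(=O)/c(=C\c2cc(F)ccc2C)[nH]c(=O)/c1=C\c1ccccc1OC` keeps the shared core of compound 1; the change is 5-fluoro-2-methylphenyl in place of 3,4-dichlorophenyl on a double-bonded chain carbon bound to an aromatic carbon. Going by the values given here, no pair with a measured step shows what such a swap does in this assay, so the size of the step is unknown. Given that compound 1 gives "not active" (no number reported), compound 4 is expected to remain weak, most likely again without a reported number, with an estimate of 20000 nM and a range from 3000 nM to 100000 nM.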

Compound 4, half-maximal inhibitory concentration: 1000 nM
Estimate against measurement, compound 4: 20-fold (1.30 log units) above, outside the stated range (below it).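

In this assay compound 1 has no number, so no step to compound 4 can be read, and no measurement shown explains the result. As far as these compounds go, how far the swap to 5-fluoro-2-methylphenyl alone moves the reading stays open.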